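The compounds below may be only part of what the source reports. "The series", "measured", "known", "first", "only" and "open" are said of these compounds alone.

Of the compounds shown here, two have numbers so far in a functional assay (Homo sapiens) for antiproliferative activity, read by sulforhodamine B assay, with a stated time of 48 h; on this read-out higher numbers stand for weaker inhibition and lower numbers for stronger inhibition. Compound 1 (`COc1cc(NS(=O)(=O)c2ccc(N3CCNC3=O)cc2)cc(OC)c1OC`) gives 58 nM. Compound 2 (`Cc1cc(C)cc(NS(=O)(=O)c2ccc(N3CCNC3=O)cc2)c1`) gives 260 nM, the higher of the two numbers and beyond the scatter from compound 1, so it stands as the weaker inhibitor of the pair. Compound 3 (`COc1cccc(NS(=O)(=O)c2ccc(N3CCNC3=O)cc2)c1`) has not yet been measured. It carries 3-methoxyphenyl in place of 3,5-dimethylphenyl on a sulfonamide nitrogen. For the measured compounds named here, no single-place step between measured compounds is available, so the expectation rests on two values and this change alone. Compound 1, which also bears methoxy groups, gives 58 nM, which argues against a large loss. The expected change is small and not beyond the scatter, slightly toward weaker inhibition: a 1.2-fold higher number from compound 2 to compound 3 (0.06 log units; within the scatter). The estimate for compound 3 is 300 nM, with an expected range of 90 nM to 1000 nM.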

Compound 3, half-maximal inhibitory concentration: 370 nM
The estimate for compound 3 lay 1.2-fold (0.09 log units) below the measured number; the range from low to high includes it.
By their numbers in this assay, from the lowest: compound 1; then compounds 2 and 3 (each within the scatter of the next).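

In this assay, for the compounds shown here, replacing 3,5-dimethylphenyl with 3-methoxyphenyl on a sulfonamide nitrogen gives the only single-place step so far, with a 1.4-fold higher number from compound 2 to compound 3 (0.15 log units; within the scatter). This read-out therefore does not separate the two groups at this position, although the entering group has one hydrogen-bond acceptor and the leaving group has none. Nothing at hand bears on the basis of this result.

Compound 1 (58 nM) differs from compound 2 and compound 3 in more than one place, so no single change can be held to account for its value. Also open, going by these compounds, is how this position responds to a phenyl ring bearing an amine or a carboxylic acid, or to a longer alkyl chain in place of the ring.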